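The compounds below may be only part of what the source reports. "The series", "measured", "known", "first", "only" and "open" are said of these compounds alone.

Compound 1 `CCC(=O)N(C)c1ccc2[nH]c(-c3n[nH]c4ccccc34)cc2n1` gives 33500 nM in a functional assay on SMMC-7721 cells (Homo sapiens) for antiproliferative activity, read by MTT assay, with a stated time of 72 h; on this read-out lower numbers stand for stronger inhibition and higher numbers for weaker inhibition. Compound 2 `CN(C(=O)c1ccc(Br)cc1)c1ccc2[nH]c(-c3n[nH]c4ccccc34)cc2n1` gives 3460 nM.

Compound 2 holds the lower of the two numbers, set apart by the step of a 9.7-fold lower number from compound 1 to compound 2 (0.99 log units; beyond the scatter). Compound 3 `COc1ccc(C(=O)N(C)c2ccc3[nH]c(-c4n[nH]c5ccccc45)cc3n2)cc1` keeps the shared core and the carbonyl and differs in one place: methoxy in place of bromo on an aromatic carbon. Among the compounds with values here, no measured step exchanges one group for another on the aromatic ring; the single step on record, a 9.7-fold lower number from compound 1 to compound 2 (0.99 log units; beyond the scatter), shows that the group on the carbonyl matters but says nothing about bromo against methoxy. A change within the scatter, or a small rise, is expected. Compound 3 is therefore estimated at 5000 nM, with a range from 1500 nM to 16000 nM. The expected step is a 1.4-fold higher number from compound 2 to compound 3 (0.16 log units; within the scatter).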

Compound 3, half-maximal inhibitory concentration: 23700 nM
Estimate against measurement, compound 3: 4.7-fold (0.68 log units) below, outside the stated range (above it).
By their numbers in this assay, from the lowest: compound 2; then compounds 3 and 1 (each within the scatter of the next).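

Changing only the group on this aromatic carbon, para to a large group, has a clear effect in this assay: methoxy in place of bromo gives a 6.8-fold higher number from compound 2 to compound 3 (0.84 log units; beyond the scatter) with nothing else altered. Swapping ethyl on the carbonyl for 4-methoxyphenyl gives only a 1.4-fold lower number from compound 1 to compound 3 (0.15 log units; within the scatter) and so shows that the phenyl ring alone does not carry the gain seen with 4-bromophenyl. Nothing available explains the difference between bromo and methoxy.

As far as these compounds go, it remains open whether the gain is specific to bromo or would also appear with chloro or fluoro. An amine or a carboxylic acid at this place is also untested in the compounds shown here.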